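This account rests on a few compounds, and the source may have more. Where it says the series, first, only, none or still open, it means among the compounds named here.

Measured so far in a functional assay on the whole organism (strain albino Sprague-Dawley) with Rattus norvegicus as the target, in the maximal electroshock model; a higher number here means that more compound is needed for the effect, a lower number that less compound is needed:
compound 1, `CC(C)(C)[C@@H](N)C(=O)NCc1ccc(COc2cccc(F)c2)cc1`: 30 mg/kg
compound 2, `CC(C)[C@@H](N)C(=O)NCc1ccc(F)cc1`: 21 mg/kg
compound 3, `CC(C)(C)[C@@H](N)C(=O)NCc1ccccc1`: 11 mg/kg

Compound 1 carries the highest number of the three in this assay. Compound 2 stands nearest; its number and that of compound 1 lie within the usual scatter of each other, so nothing separates the two. Compound 3 gives a number that is clearly lower than that of compound 1, beyond the scatter: less of compound 3 is needed for the same effect. Within the data shown here, none of these pairs differ in only one place, so no single structural step is isolated among the measured compounds; each pair shows only what its two values show.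

The compound to be measured is compound 4, `COC[C@@H](N)C(=O)NCc1ccc(COc2cccc(F)c2)cc1`. It differs from compound 1 in one place:
methoxymethyl in place of tert-butyl on a saturated chain carbon bound to an amine nitrogen and a carbonyl carbon
Among the measured compounds shown here, no measured pair covers this change, so the expectation rests on the spread of the three numbers and on the change itself. A step toward a higher number in this assay is expected for compound 4, modest in size and not certain to clear the scatter. Compound 4 is estimated at 60 mg/kg, with a range from 25 mg/kg to 150 mg/kg. The expected step is a 2.0-fold higher number from compound 1 to compound 4 (0.30 log units; within the scatter).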

Compound 4, dose for half-maximal effect: 12 mg/kg
Beside the measured number, compound 4's estimate is 5.0-fold (0.70 log units) above it; measured number outside the range, below it.
By their numbers in this assay, from the lowest: compounds 3, 4, 2 and 1 (each within the scatter of the next, the first and the last beyond it).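

Among these compounds, the change from tert-butyl to methoxymethyl, on a saturated chain carbon bound to an amine nitrogen and a carbonyl carbon, gives in this assay a 2.5-fold lower number from compound 1 to compound 4 (0.40 log units; beyond the scatter), the first single-place step and one beyond the scatter. With the rest of the core of compound 1 held fixed, this position does not depend on tert-butyl for the effect: the all-carbon group can give way to methoxymethyl, which brings a hydrogen-bond acceptor, and less compound is needed. No measured property of either group is at hand for this step, and no cause can be assigned to it.

A single step cannot separate the contribution of the oxygen in methoxymethyl from that of the loss of tert-butyl; hydroxymethyl, ethoxymethyl or a plain ethyl group at the same place would help to tell these apart. Going by these compounds, whether the same change gives a step of similar size on the core of compound 3, which also carries tert-butyl at this place, remains open.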